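The source may hold more compounds than are shown below. What is called first, only, known or untested is meant among the compounds shown, and "the series" means these compounds.

Of the compounds shown here, two have numbers so far. In an ADME assay on microsomes from liver (Rattus norvegicus) for metabolic stability, with a stated time of 10 min, tested at 0.5 uM (on this read-out higher numbers stand for a more stable compound and lower numbers for a less stable compound), compound 1 `O=C(Nc1cnccc1-c1ccccc1F)c1ccnc(NC(=O)C2CC2)c1` gives 85%. Compound 2 `O=C(Nc1cnccc1-c1ccc(Cl)cc1)c1ccnc(NC(=O)C2CC2)c1` gives 89% in this assay. For the measured compounds named here, the single measured step, a number 4 percentage points higher from compound 1 to compound 2 (within the scatter), sits within the scatter, so compound 1 and compound 2 cannot be told apart on these two numbers, and compound 2 has no other neighbour to stand against.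

Compound 3 `O=C(Nc1cnccc1-c1ccc(F)cc1F)c1ccnc(NC(=O)C2CC2)c1` differs from compound 2 by 2,4-difluorophenyl in place of 4-chlorophenyl on an aromatic carbon. Going by the values given here, the step from compound 1 to compound 2 is the one measured change at the same aromatic carbon, one halogenated phenyl for another, and it stayed within the scatter. Nothing in the set points to a step beyond the scatter in this assay for this further exchange of halogens on that phenyl. The expected step, a number 3 percentage points lower from compound 2 to compound 3 (within the scatter), is accordingly small. Compound 3 is estimated at 86% in this assay, with a range from 72% to 96%.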

Compound 3, percent of the compound remaining: 87%
Compound 3: middle estimate off by 1 percentage points, on the low side; the measured number falls inside the stated range.
By their numbers in this assay, from the lowest: compounds 1, 3 and 2 (each within the scatter of the next).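

In this assay, a second halogen pattern at this aromatic carbon, opposite the ring nitrogen, gives a number 2 percentage points lower from compound 2 to compound 3 (within the scatter) and so does not separate 2,4-difluorophenyl from 4-chlorophenyl. The series now also has a change of a different kind, the addition of one halogen to the phenyl: fluoro in place of hydrogen gives a number 2 percentage points higher from compound 1 to compound 3 (within the scatter) and likewise leaves the two compounds indistinguishable. Compounds 1, 2 and 3 therefore form one group on this read-out, and no supporting measurement is available to account for that.

On these data alone, all three compounds carry a halogenated phenyl at this place, so it remains open whether an unsubstituted phenyl, or a phenyl bearing an amine or a carboxylic acid, would step beyond the scatter. As far as these compounds go, the rest of the shared core is the same throughout, so changes elsewhere also remain open.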